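Compound 3 to compound 4: ethyl becomes isopropyl

This account rests on a few compounds, and the source may have more. Where it says the series, first, only, none or still open, it means among the compounds named here.

Of the compounds shown here, three have been tested so far in an in vitro ADME assay on microsomes (Mus musculus) for metabolic stability, read by LC-MS, with a stated time of 15 min; a lower number here means that the compound disappears faster, a higher number that the compound lasts longer. Compound 1 (`O=C(Nc1ccc(CO)cc1)Nc1ccc(-c2nc(N3C4CCC3COC4)nc(N3C4CCC3COC4)n2)cc1`) gives > 0.5 h as a limit of the assay, not an exact number. Compound 2 (`CN1CCN(c2ccc(NC(=O)Nc3ccc(-c4nc(N5C6CCC5COC6)nc(N5[C@H](CO)CC[C@@H]5CO)n4)cc3)cc2)CC1`) gives > 0.5 h, also a limit. Compound 3 (`CCN1CCN(c2ccc(NC(=O)Nc3ccc(-c4nc(C5CCOCC5)nc(N5C6CCC5COC6)n4)cc3)cc2)CC1`) gives > 0.5 h, again a limit. That leaves all three together at one point: the limit of > 0.5 h in this assay, at which 3 of the 3 values shown sit. Compound 4 (`CC(C)N1CCN(c2ccc(NC(=O)Nc3ccc(-c4nc(C5CCOCC5)nc(N5C6CCC5COC6)n4)cc3)cc2)CC1`) differs from compound 3 in one place, where 4-ethylpiperazin-1-yl becomes 4-isopropylpiperazin-1-yl (methyl in place of hydrogen on a saturated chain carbon bound to an amine nitrogen in a ring and a saturated chain carbon). Within the data shown here, no measured step shows what such a change does, so no shift beyond the usual scatter is expected, in either direction. The expected step is a step that the limit leaves unreadable from compound 3 to compound 4 in size. For compound 4 the estimated half-life is 0.6 h, with an expected range of 0.3 h to 1.2 h.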

Compound 4, half-life: > 0.5 h
Compound 4: only a limit was reported; the forecaster's own chance of this, stated with the estimate: 75%; the middle value is on the limit's open side.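

Compound 3 and compound 4 both give only a limit in this assay, so the step from ethyl to isopropyl cannot be read. The actual half-life of each compound shown stays open, and with it any difference among them: the limit of > 0.5 h in this assay, at which 4 of the 4 values shown sit.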